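Two Fluorines in Place of Two Methyl Groups

The compounds below may be only part of what the source reports. "The series", "measured", "known", "first", "only" and "open" are said of these compounds alone.

In a functional assay on MCF7 cells (Homo sapiens) for cytotoxicity, read by MTT assay, with a stated time of 72 h (on this read-out lower numbers stand for stronger inhibition and higher numbers for weaker inhibition), compound 3 `Cc1ccc(-c2ccnc(C(=O)Nc3ccc(Oc4ccnc5[nH]ccc45)c(F)c3)c2)c(C)c1` gives 6220 nM, the lower of the two numbers shown. Compound 2 `Cc1cccc(-c2ccnc(C(=O)Nc3ccc(Oc4ccnc5[nH]ccc45)cc3)c2)c1` gives 7470 nM in this assay, a value within the scatter of compound 3. Compound 1 `O=C(Nc1ccc(Oc2ccnc3[nH]ccc23)cc1)c1ccc(-c2ccc(F)cc2F)cn1` gives > 10000 nM in this assay, which is a limit of the assay rather than a number. Compound 4 `O=C(Nc1ccc(Oc2ccnc3[nH]ccc23)c(F)c1)c1cc(-c2ccc(F)cc2F)ccn1` has not yet been measured; it differs from compound 3 in one place: 2,4-difluorophenyl in place of 2,4-dimethylphenyl on an aromatic carbon. Compound 1 also carries a 2,4-difluorophenyl group. Compound 4 is expected to show weaker inhibition, a step of a 1.4-fold higher number from compound 3 to compound 4 (0.16 log units; within the scatter) in this assay. The estimate for compound 4 is 9000 nM, between 4000 nM and 20000 nM.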

Compound 4, half-maximal inhibitory concentration: > 10000 nM
Compound 4: a limit, no number; the forecaster's own chance of this, stated with the estimate: 40%; middle value at least 1.1-fold (0.04 log units) away from the limit.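

Among the compounds shown here, this is the first comparison at this position, opposite the ring nitrogen, that changes only one group: 2,4-difluorophenyl in place of 2,4-dimethylphenyl gives, in this assay, an at least 1.6-fold higher number from compound 3 to compound 4 (0.20 log units; that floor lies within the scatter). From the compounds shown here alone, compound 4 stands at a limit of the assay and not at a number, so only a floor for this step can be read, and the true size of the change stays unknown. Compound 4 shares that ceiling with compound 1: the limit of > 10000 nM in this assay, at which 2 of the 4 values shown sit.

Open, going by these compounds, is whether an amine or a carboxylic acid in place of the phenyl group at this position would give a lower number.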